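The compounds below may be only part of what the source reports. "The series", "measured", "known", "first", "only" and "open" are said of these compounds alone.

For the measured compounds named here, in an ADME assay on L6 cells (Rattus norvegicus) for cytotoxicity (a higher number here means a weaker inhibitor, a lower number a stronger inhibitor), three compounds built on a shared core have numbers so far. Compound 1 (`COc1cc2c(cc1C(C)OCc1ccccc1)C=CC(C)(C)O2`) gives 43900 nM, compound 2 (`COc1cc2c(cc1C(C)NC(=O)c1ccccc1)C=CC(C)(C)O2`) gives 34800 nM, and compound 3 (`COc1cc2c(cc1C(C)N[C@@H](C)c1ccccc1)C=CC(C)(C)O2`) gives 16500 nM, the lowest of the three. The next compound, compound 4 (`CCNC(C)c1cc2c(cc1OC)OC(C)(C)C=C2`), departs from compound 3 as follows: hydrogen in place of phenyl on a saturated chain carbon bound to an amine nitrogen and a saturated chain carbon. This places hydrogen in place of phenyl on a saturated chain carbon bound to an amine nitrogen and a saturated chain carbon, so that 1-phenylethyl becomes ethyl. Going by the values given here, only one measured step bears on this change, and only indirectly: a 2.1-fold lower number from compound 2 to compound 3 (0.32 log units; beyond the scatter), a modest move with 1-phenylethyl in place of benzoyl on an amine nitrogen. All three measured compounds carry a phenyl ring, so the data hold no direct measure of its loss. With compound 3 at the low end, a modest rise of similar size is expected in this assay. The expected step is a 2.1-fold higher number from compound 3 to compound 4 (0.33 log units; beyond the scatter). The estimate for compound 4 is 35000 nM, with an expected range from 15000 nM to 80000 nM.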

Compound 4, half-maximal inhibitory concentration: 176000 nM
Beside the measured number, compound 4's estimate is 5.0-fold (0.70 log units) below it; the whole stated range lies below it.
By their numbers in this assay, from the lowest: compound 3; then compounds 2 and 1 (each within the scatter of the next); then compound 4.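

In this assay, for the compounds shown here, the loss of phenyl at this place gives an 11-fold higher number from compound 3 to compound 4 (1.03 log units; beyond the scatter) and is the first direct measure of that ring, whose removal from 1-phenylethyl is a large step rather than a modest one. Ethyl in place of benzoyl on the amine nitrogen gives a 5.1-fold higher number from compound 2 to compound 4 (0.70 log units; beyond the scatter) in the same direction, and ethylamino in place of benzyloxy gives a 4.0-fold higher number from compound 1 to compound 4 (0.60 log units; beyond the scatter) as well, so the one compound without the terminal phenyl ring has the highest number of the four. Nothing available accounts for the size of this rise.

As far as these compounds go, whether a cyclohexyl ring, a pyridine ring or a longer chain on this saturated chain carbon would keep the number near that of compound 3 remains open. So does the effect of a methyl group alone in place of the phenyl.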